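The source may report more compounds than this note shows. Statements on the series, on what has been measured and on what is new or still open speak of the compounds shown alone.

Measured so far in a functional assay (Cavia porcellus) with sulfonylurea receptors; K-ATP channels (Homo sapiens) as the target; a higher number here means a weaker inhibitor, a lower number a stronger inhibitor:

compound 1 `CC(O)(C(=O)Nc1ccc(S(=O)(=O)c2ccccc2)c(F)c1)C(F)(F)F` — 1800 nM
compound 2 `CC(O)(C(=O)Nc1ccc(S(=O)(=O)c2ccccc2F)cc1)C(F)(F)F` — 1300 nM
compound 3 `CC(O)(C(=O)Nc1ccc(S(=O)(=O)c2ccccc2)c(O)c1)C(F)(F)F` — 430 nM

Compound 2 stands second highest of the three numbers; its gap to compound 1 lies within the scatter, while compound 3 sits a clear step lower. Among the compounds with values here, the only single-point step measured, a 4.2-fold lower number from compound 1 to compound 3 (0.62 log units; beyond the scatter), concerns the other aromatic ring and so does not bear on the sulfonyl-bound ring. Compound 4 `CC(O)(C(=O)Nc1ccc(S(=O)(=O)c2cccc(Cl)c2)cc1)C(F)(F)F` differs from compound 2 in that ring: 3-chlorophenyl in place of 2-fluorophenyl on a sulfonyl sulfur. Within the data shown here, no measured pair changes the substituent on the sulfonyl-bound phenyl, so no step beyond the scatter is expected in this assay for compound 4, whose value is estimated at 1100 nM (range 400 nM to 3000 nM), corresponding to an expected 1.2-fold lower number from compound 2 to compound 4 (0.07 log units; within the scatter).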

Compound 4, half-maximal inhibitory concentration: 10000 nM
For compound 4 the middle estimate is 9.1-fold (0.96 log units) below the measured one; the whole stated range lies below it.
By their numbers in this assay, from the lowest: compound 3; then compounds 2 and 1 (each within the scatter of the next); then compound 4.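

The phenyl on the sulfonyl sulfur is not a silent place in this assay: 3-chlorophenyl in place of 2-fluorophenyl gives a 7.7-fold higher number from compound 2 to compound 4 (0.89 log units; beyond the scatter) and so a weaker inhibitor. Within the data shown here, this is the first measured change in this ring, and it moves the number by more than the scatter. Nothing at hand gives a reason for this step.

The step changes the halogen and its place on the phenyl together, and the compounds shown do not separate the two. On these data alone, how a methoxy group or an amine on this phenyl would read also stays open.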